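Swapping 3-cyanophenyl for 4-acetylphenyl in the series

This account rests on a few compounds, and the source may have more. Where it says the series, first, only, none or still open, it means among the compounds named here.

In a functional assay on DU-145 cells (Homo sapiens) for inhibition (a lower number here means a stronger inhibitor, a higher number a weaker inhibitor), compound 1 `CCOc1ccc(Br)cc1-c1cc(Nc2ccc(B(O)O)cc2)nc(N)n1` gives 500 nM. Compound 2 `CCOc1ccc(Br)cc1-c1cc(Nc2cccc(C#N)c2)nc(N)n1` has no exact number, and its entry is a limit: > 1000 nM.

The next analogue is compound 3 `CCOc1ccc(Br)cc1-c1cc(Nc2ccc(C(C)=O)cc2)nc(N)n1`, which keeps the shared core and changes only the group on the nitrogen: 4-acetylphenyl in place of 3-cyanophenyl on a nitrogen on an aromatic ring. Among the measured compounds shown here, the only measured step at this place is the one leading to compound 2, and it gives little guidance on size or direction. For the measured compounds named here, no step clearly beyond the scatter is expected in this assay because an at least 2.0-fold higher number from compound 1 to compound 2 (0.30 log units; that floor lies within the scatter) has a floor that lies within the scatter.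

For compound 3, the estimated value is 1000 nM, with an expected range of 400 nM to 2500 nM. The expected step is a number no higher from compound 2 to compound 3 (the limit leaves the size open).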

Compound 3, half-maximal inhibitory concentration: 90 nM
Estimate against measurement, compound 3: 11-fold (1.05 log units) above, outside the stated range (below it).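

In this assay, the group on the nitrogen now shows a clear effect: 4-acetylphenyl in place of 3-cyanophenyl gives an at least 11-fold lower number from compound 2 to compound 3 (1.04 log units; beyond the scatter), whereas the earlier step at this place had a floor within the scatter. The group on the aromatic carbon also counts, since the acetyl group in place of the boronic acid gives a 5.6-fold lower number from compound 1 to compound 3 (0.74 log units; beyond the scatter). The step from compound 2 remains a floor, as the entry for compound 2 is only a limit: the limit of > 1000 nM in this assay, at which 1 of the 3 values shown sits.

The names 3-cyanophenyl and 4-acetylphenyl differ in both the group and its number on the ring, so 4-cyanophenyl and 3-acetylphenyl would be needed to separate the two. On these data alone, how a carboxylic acid, an amide or an amine at the 4-position compares with the acetyl group remains open.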